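Removing the tert-butoxycarbonyl group from a pyrrolidin-3-yl compound

This account rests on a few compounds, and the source may have more. Where it says the series, first, only, none or still open, it means among the compounds named here.

For the measured compounds named here, compound 3 (`CN1CCN(c2ccc(Nc3ncc4nc(Nc5ccccc5)n([C@H]5CCN(C(=O)OC(C)(C)C)C5)c4n3)cc2)CC1`) gives 110 nM in a functional assay on HCC827 cells (Homo sapiens) for antiproliferative activity, read by MTT assay, with a stated time of 72 h (a higher number here means a weaker inhibitor, a lower number a stronger inhibitor), and takes the middle place among the three numbers known so far. Compound 1 (`CN1CCN(c2ccc(Nc3ncc4nc(Nc5ccc(F)cc5)n([C@@H]5CCN(C(=O)CO)C5)c4n3)cc2)CC1`) reads higher (350 nM) and compound 2 (`CN1CCN(c2ccc(Nc3ncc4nc(Nc5ccc(F)cc5)n(-c5cccc(NC(=O)CO)c5)c4n3)cc2)CC1`) reads lower (7.5 nM). The next compound is compound 4 (`CN1CCN(c2ccc(Nc3ncc4nc(Nc5ccccc5)n([C@@H]5CCNC5)c4n3)cc2)CC1`), which has pyrrolidin-3-yl in place of 1-(tert-butoxycarbonyl)pyrrolidin-3-yl on an aromatic nitrogen. Going by the values given here, no measured pair shows this exact change. Among the compounds with values here, the one measured step at that nitrogen is large: a 47-fold lower number from compound 1 to compound 2 (1.67 log units; beyond the scatter) with 3-(((hydroxymethyl)carbonyl)amino)phenyl in place of 1-((hydroxymethyl)carbonyl)pyrrolidin-3-yl. That step replaces the whole group, so it shows that the number can move far with what sits on this nitrogen, but it gives no size for losing the tert-butoxycarbonyl group alone. The closest guide is compound 1 (350 nM), which also keeps a substituted pyrrolidin-3-yl ring, although it differs from compound 3 in more than one place. A modest move toward weaker inhibition is therefore expected, and the estimate amounts to a 2.7-fold higher number from compound 3 to compound 4 (0.44 log units; beyond the scatter) in this assay with wide uncertainty. Compound 4 is estimated at 300 nM with an expected range of 80 nM to 1100 nM until its measurement is known.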

Compound 4, half-maximal inhibitory concentration: 65 nM
Compound 4: the middle estimate sits 4.6-fold (0.66 log units) above what was measured; measured number outside the range, below it.
By their numbers in this assay, from the lowest: compound 2; then compounds 4 and 3 (each within the scatter of the next); then compound 1.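

In this assay, the step is a 1.7-fold lower number from compound 3 to compound 4 (0.23 log units; within the scatter), so 1-(tert-butoxycarbonyl)pyrrolidin-3-yl and pyrrolidin-3-yl on this aromatic nitrogen cannot be told apart, even though the group leaving has 12 heavy atoms and the group entering has 5. For the compounds shown here, the only earlier step at this nitrogen, a 47-fold lower number from compound 1 to compound 2 (1.67 log units; beyond the scatter), lay beyond the scatter but replaced the whole group, whereas this one shows that removing the tert-butoxycarbonyl group from the pyrrolidin-3-yl ring, which leaves a ring nitrogen carrying a hydrogen-bond donor, need not move the number beyond the scatter. No measured property of these groups accompanies the result, so it offers no explanation for this outcome.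

The compounds shown leave open whether a methyl or acetyl group on the pyrrolidine nitrogen, or a piperidin-4-yl ring in place of the pyrrolidin-3-yl ring, would also stay within the scatter of these two compounds. They also leave open what the hydroxyacetyl group of compound 1 contributes on its own, since that compound differs from compound 3 and compound 4 in more than one place, including a fluorine on the anilino group.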